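The source may hold more compounds than are shown below. What is called first, only, known or untested is meant among the compounds shown, and "the series" means these compounds.

Working notes on a small set of benzylamide derivatives of a chlorinated or amino-substituted aromatic core, all tested for toxicity toward cultured cells.

Compound 1, `O=C(NCc1ccccc1)c1cncc(Cl)n1`, carries a chlorine on the core; in an ADME assay on MDCK cells (Canis lupus familiaris) for cytotoxicity, read by microscopy, with a stated time of 6 days (on this read-out lower numbers stand for higher toxicity in this test and higher numbers for lower toxicity in this test), compound 1 is recorded as "not determined" (no result reported). Compound 2, `CCCCCCCCNc1cncc(C(=O)NCc2ccccc2)n1`, carries an octylamino chain on the same core, and in this assay compound 2 gives 4000 nM. Compound 3, `CCCCCNc1cnc(C(=O)NCc2ccccc2)cn1`, carries a pentylamino chain on a differently arranged core. In this assay compound 3 reaches only a limit of the test, > 100000 nM, not a number. Taken together, compound 2 holds the only real number in the set; the other value is the limit (the limit of > 100000 nM in this assay, at which 1 of the 3 values shown sits), and compound 1 is without a result.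

Compound 4, `CCCCCCNc1cncc(C(=O)NCc2ccccc2)n1`, is not yet measured. Against compound 2 the change is hydrogen in place of ethyl on a saturated chain carbon, six bonds along the chain from a nitrogen on an aromatic ring.

Among the measured compounds shown here, no step between measured compounds is available, so the size of the effect of shortening the chain rests on the two values shown. Compound 2 gives 4000 nM. Compound 3, with a shorter chain, sits at the limit of the test. On that basis the step of a 5.0-fold higher number from compound 2 to compound 4 (0.70 log units; beyond the scatter) is expected to run toward lower toxicity and to exceed the usual scatter. Compound 4 is therefore estimated at 20000 nM, with a range from 6000 nM to 100000 nM.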

Compound 4, minimum cytotoxic concentration: 20000 nM
The estimate for compound 4 equals the measured number at the digits printed, and the stated range covers the measured number.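

Among the compounds shown here, with hydrogen in place of ethyl on a saturated chain carbon, six bonds along the chain from a nitrogen on an aromatic ring, this assay gives the first step between compounds that differ in one place: a 5.0-fold higher number from compound 2 to compound 4 (0.70 log units; beyond the scatter). On the shared core, the outer part of the chain therefore matters to this read-out, and the shorter chain of compound 4 goes with lower toxicity in this test than the octylamino chain of compound 2. The other entry in the series that carries an amino chain belongs to compound 3, whose core is arranged differently, and it remains a limit and not a number: the limit of > 100000 nM in this assay, at which 1 of the 4 values shown sits.

For the compounds shown here, the single step gives two points on one core and no trend, so it remains open whether a pentylamino or butylamino chain on that core would continue the direction, or whether a longer chain such as decylamino would reverse it. Going by these compounds, it is equally open how a chain ending in a hydroxyl group, an amine or a carboxylic acid would read in this assay, and the part played by the core arrangement of compound 3 cannot be separated from that of its chain.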